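The source may hold more compounds than are shown below. What is called first, only, known or untested is meant among the compounds shown, and "the series" means these compounds.

Going by the values given here, compound 3 `COc1cc(-c2nn(-c3cccc(NC(=O)Nc4ccc(Cl)c(C(F)(F)F)c4)c3)cc2-c2ccncc2)ccc1Cl` is the one member of this set for which a functional assay on TK-10 cells (Homo sapiens) for inhibition, read by sulforhodamine B assay, with a stated time of 48 h (a lower number here means a stronger inhibitor of growth, a higher number a weaker inhibitor of growth), returns a number: compound 3 gives 13500 nM. Compound 1 `O=C(Nc1cccc(-n2cc(-c3ccncc3)c(-c3ccc(Cl)c(O)c3)n2)c1)Nc1cccc(C(F)(F)F)c1` carries the hydroxy group and a 3-(trifluoromethyl)phenyl on the amide-type nitrogen; in this assay compound 1 sits at a limit, > 32500 nM. Compound 2 `O=C(Nc1cccc(-n2cc(-c3ccncc3)c(-c3ccc(Cl)c(O)c3)n2)c1)Nc1ccc(Cl)c(Cl)c1` likewise sits at a limit in this assay, > 32500 nM. The step that the two limits leave unreadable from compound 1 to compound 2 is accordingly not readable, both values resting at the limit of > 32500 nM in this assay, at which 2 of the 3 values shown sit. Compound 4 `O=C(Nc1cccc(-n2cc(-c3ccncc3)c(-c3ccc(Cl)c(O)c3)n2)c1)Nc1ccc(Cl)c(C(F)(F)F)c1` differs from compound 3 by hydrogen in place of methyl on an oxygen on an aromatic ring. Among the compounds with values here, no measured step touches this position, so the bearing is indirect: the two hydroxy compounds 1 and 2 give no number in this assay, while the methoxy compound 3 does. The change is therefore expected to weaken compound 4, most likely back toward the limit, by a 2.2-fold higher number from compound 3 to compound 4 (0.35 log units; beyond the scatter). Compound 4 is expected to give 30000 nM in this assay, with a range of 10000 nM to 90000 nM.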

Compound 4, concentration for total growth inhibition: 11900 nM
Compound 4: the middle estimate sits 2.5-fold (0.40 log units) above what was measured, within the range that was stated.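

In this assay, methoxy to hydroxy on the aromatic ring gives a 1.1-fold lower number from compound 3 to compound 4 (0.05 log units; within the scatter), so with 4-chloro-3-(trifluoromethyl)phenyl on the amide-type nitrogen this change leaves the read-out unmoved, and the hydroxy group alone does not hold a compound at the limit. Among the hydroxy compounds, the group on the amide-type nitrogen now matters, with trifluoromethyl in place of chloro giving an at least 2.7-fold lower number from compound 2 to compound 4 (0.43 log units; beyond the scatter) and chloro in place of hydrogen giving an at least 2.7-fold lower number from compound 1 to compound 4 (0.43 log units; beyond the scatter). Both steps start from a limit rather than a number, so their true sizes stay unfixed: the limit of > 32500 nM in this assay, at which 2 of the 4 values shown sit.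

On these data alone, how an amine or a carboxylic acid in place of the hydroxy group would read in this assay remains open. So does the size of the methoxy to hydroxy change with other groups on the amide-type nitrogen.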